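This account rests on a few compounds, and the source may have more. Where it says the series, first, only, none or still open, it means among the compounds named here.

Working notes on the series. The shared core carries a substituent on the oxygen of the aromatic ring; compound 1 `COc1ccc2c(c1)C(=O)C=CC2=O` bears methyl there, compound 2 `CC(=O)Oc1ccc2c(c1)C(=O)C=CC2=O` acetyl, compound 3 `C=CCOc1ccc2c(c1)C(=O)C=CC2=O` allyl. In a functional assay on HeLa cells (Homo sapiens) for cytotoxicity (a lower number here means a stronger inhibitor, a higher number a weaker inhibitor), compound 1 gives 22700 nM, compound 2 gives 27700 nM and compound 3 gives 27200 nM. All three sit within the scatter of one another: a 1.2-fold higher number from compound 1 to compound 2 (0.09 log units; within the scatter), a 1.2-fold higher number from compound 1 to compound 3 (0.08 log units; within the scatter), a 1.0-fold lower number from compound 2 to compound 3 (0.01 log units; within the scatter). Compound 3 has the second highest of the three numbers, nearest to compound 2 and furthest from compound 1, with neither gap beyond the scatter.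

Compound 4 `CCOc1ccc2c(c1)C(=O)C=CC2=O` differs from compound 3 as follows: methyl in place of vinyl on a saturated chain carbon bound to an oxygen on an aromatic ring. The step bearing on it is that from compound 1 to compound 3, where vinyl entered at the same place and the number moved only a 1.2-fold higher number from compound 1 to compound 3 (0.08 log units; within the scatter). Removing the vinyl part again, with methyl in its place, is therefore expected to move the number no further than the scatter in this assay, in no set direction, so that the step of a 1.1-fold lower number from compound 3 to compound 4 (0.04 log units; within the scatter) is the estimate. Compound 4 is expected to give about 25000 nM, in the range 12000 nM to 50000 nM.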

Compound 4, half-maximal inhibitory concentration: 25100 nM
Compound 4: the middle estimate sits 1.0-fold (0.00 log units) below what was measured; low and high end bracket the measured number.
By their numbers in this assay, from the lowest: compounds 1, 4, 3 and 2 (each within the scatter of the next).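

At this place on the oxygen, going from allyl to ethyl gives a 1.1-fold lower number from compound 3 to compound 4 (0.03 log units; within the scatter) in this assay, so the loss of the double bond outside aromatic rings leaves the number within the scatter. Adding one carbon to methyl without any vinyl gives a 1.1-fold higher number from compound 1 to compound 4 (0.04 log units; within the scatter) and replacing acetyl with ethyl gives a 1.1-fold lower number from compound 2 to compound 4 (0.04 log units; within the scatter) as the series reads, so methyl, ethyl, allyl and acetyl on this oxygen all lie within the scatter of one another. No supporting data are available to explain this flat picture.

On these data alone, whether a longer chain such as octyl, or a chain ending in an amine or a carboxylic acid, would stay within the scatter remains open. The compounds shown also do not tell how a change elsewhere on the shared core would read.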